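Removing the chloro from the dihydroindole of compound 3

The source may report more compounds than this note shows. Statements on the series, on what has been measured and on what is new or still open speak of the compounds shown alone.

Compound 1: `Nc1ccccc1NC(=O)c1ccc(CSC(=S)N2CCN(c3ccncc3)CC2)cc1` — 2490 nM
Compound 2: `Nc1ccccc1NC(=O)c1ccc(CSC(=S)N2CCN(c3ccc(F)cc3)CC2)cc1` — 980 nM
Compound 3: `Nc1ccccc1NC(=O)c1ccc(CSC(=S)N2CCc3cc(Cl)ccc32)cc1` — 3280 nM

In a functional assay on NCI-H1299 cells (Homo sapiens) for antiproliferative activity, read by CCK-8 assay, with a stated time of 72 h (on this read-out lower numbers stand for stronger inhibition and higher numbers for weaker inhibition), compound 3 gives 3280 nM, a number that sits within the scatter of compound 1 and beyond the scatter from compound 2. For the measured compounds named here, the only measured step, a 2.5-fold lower number from compound 1 to compound 2 (0.40 log units; beyond the scatter), concerns a different part of the shared core and does not bear on the change to compound 4, `Nc1ccccc1NC(=O)c1ccc(CSC(=S)N2CCc3ccccc32)cc1`, which is hydrogen in place of chloro on an aromatic carbon. Going by the values given here, no measured step speaks to the loss of the chloro here. Compound 4 is therefore expected to stay near compound 3, with a 1.0-fold lower number from compound 3 to compound 4 (0.01 log units; within the scatter) and no step beyond the scatter foreseen. The estimate for compound 4 is 3200 nM, ranging from 1500 nM to 7000 nM.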

Compound 4, half-maximal inhibitory concentration: 2900 nM
Compound 4: the middle estimate sits 1.1-fold (0.04 log units) above what was measured; the range from low to high includes it.
By their numbers in this assay, from the lowest: compound 2; then compounds 1, 4 and 3 (each within the scatter of the next).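

In this assay, hydrogen in place of chloro in the 5-chloro-2,3-dihydro-1H-indol-1-yl group gives a 1.1-fold lower number from compound 3 to compound 4 (0.05 log units; within the scatter), so the two compounds cannot be told apart. At this aromatic carbon, the chloro is therefore not required for the activity seen on these cells. Nothing available explains why this exchange leaves the reading within the scatter.

Going by these compounds, whether a methoxy, a nitrile or a dimethylamino group on this same carbon would also stay within the scatter remains open. Also open, on these data alone, is whether a chloro on another carbon of this ring would behave the same way.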